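Benzofuran ketone series: demethylation at both phenol oxygens

A few compounds are considered here, and "the series" means these few. Any claim that something is new, unique, unknown or untested is made for them only; others in the source may bear on it.

Compound 3 `CCc1oc2ccc(O)cc2c1C(=O)c1ccc(OC)cc1` has no recorded result in an assay for inhibition of solute carrier family 22 member 12 (Homo sapiens), read by scintillation counting, with a stated time of 60 min (a higher number here means a weaker inhibitor, a lower number a stronger inhibitor), where its entry reads "not determined" (no result reported); the same holds for compound 1 `CCc1oc2ccc(OC)cc2c1C(=O)c1ccc(OC)cc1`, whose entry reads "not determined" (no result reported), so compound 3 cannot be placed on the numbers at hand. The only figure in the set comes from compound 2 `CCc1oc2ccc(OC)cc2c1C(=O)c1ccc(O)cc1`, which in this assay gives 2460 nM. Compound 2 carries the hydroxy on the benzoyl ring with the methoxy retained on the core, whereas compound 3 carries the opposite arrangement, so the two are not directly comparable by a single change.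

The step from compound 3 to compound 4 `CCc1oc2ccc(O)cc2c1C(=O)c1ccc(O)cc1` is hydrogen in place of methyl on an oxygen on an aromatic ring. Among the compounds with values here, no measured pair in the set differs in this way, so no step size can be read off. The expectation for this assay is a step in the direction of a stronger inhibitor, or none beyond the scatter, with the value of compound 2 at 2460 nM as the nearest anchor for a phenol-bearing member of the series.

Compound 4 is estimated at 1500 nM, with a range from 300 nM to 8000 nM.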

Compound 4, half-maximal inhibitory concentration: 2490 nM
Compound 4: middle estimate off by 1.7-fold (0.22 log units), on the low side, and the stated range covers the measured number.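

In this assay, within the data shown here, methoxy to hydroxy at the one methoxy retained by compound 2 gives a 1.0-fold higher number from compound 2 to compound 4 (0.01 log units; within the scatter) and so leaves no difference beyond the scatter with the other hydroxy in place. Among these compounds, this is the first measured pair for hydrogen in place of methyl on an oxygen on an aromatic ring, and it shows that a compound with two hydroxy groups keeps a number in line with that of compound 2. Nothing measured here bears on the reason for this result.

Steps involving compound 1 or compound 3 cannot be read, so the same change with a methoxy in place of the other hydroxy remains unknown. Also open, on these data alone, is whether an amine or a carboxylic acid in place of either hydroxy of compound 4 would shift the number beyond the scatter.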